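A few compounds are considered here, and "the series" means these few. Any claim that something is new, unique, unknown or untested is made for them only; others in the source may bear on it.

Measured set in a functional assay on HeLa cells (Homo sapiens) for antiproliferative activity, read by MTT assay, with a stated time of 3 days; on this read-out higher numbers stand for weaker inhibition and lower numbers for stronger inhibition:
- compound 1 `CCCCCCCCC#Cc1cn(C/C=C/CN2C(=O)c3ccccc3C2=O)c(=O)[nH]c1=O` — > 100000 nM (a limit of the assay, not a number)
- compound 2 `CCCCCC#Cc1cn(C/C=C/CN2C(=O)c3ccccc3C2=O)c(=O)[nH]c1=O` — 91000 nM
- compound 3 `O=C1c2ccccc2C(=O)N1C/C=C/Cn1cc(C#CCCc2ccccc2)c(=O)[nH]c1=O` — 29000 nM

Compound 3 gives the lowest number of the two measured values; its nearest neighbour is compound 2, with a 3.1-fold lower number from compound 2 to compound 3 (0.50 log units; beyond the scatter). Compound 1 sits at the limit described by the limit of > 100000 nM in this assay, at which 1 of the 3 values shown sits.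

Compound 4 `CCCCC#Cc1cn(C/C=C/CN2C(=O)c3ccccc3C2=O)c(=O)[nH]c1=O` carries ethyl in place of phenyl on a saturated chain carbon, two bonds along the chain from a triple-bonded carbon. The measured steps bearing on it: a 3.1-fold lower number from compound 2 to compound 3 (0.50 log units; beyond the scatter) and an at least 3.4-fold lower number from compound 1 to compound 3 (0.53 log units; beyond the scatter) both show the phenyl-bearing compound 3 with the lower number, while an at least 1.0-fold lower number from compound 1 to compound 2 (0.04 log units; that floor lies within the scatter), a shortening of the alkyl chain, stayed within the scatter. Removing the phenyl and leaving a short alkyl chain is therefore expected to raise the number back toward compound 2, a modest step of a 2.8-fold higher number from compound 3 to compound 4 (0.44 log units; beyond the scatter) in this assay. Compound 4 is estimated at 80000 nM, range 30000 nM to 200000 nM.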

Compound 4, half-maximal inhibitory concentration: 89000 nM
Compound 4: middle estimate off by 1.1-fold (0.05 log units), on the low side; low and high end bracket the measured number.
By their numbers in this assay, from the lowest: compound 3; then compounds 4 and 2 (each within the scatter of the next). At a limit, above all of these: compound 1.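

In this assay, the change from 4-phenylbut-1-yn-1-yl to hex-1-yn-1-yl gives a 3.1-fold higher number from compound 3 to compound 4 (0.49 log units; beyond the scatter), so among the values that can be read, the lower number goes with the phenyl-bearing chain. Among the alkyl chains, hydrogen in place of methyl on a saturated chain carbon, four bonds along the chain from a triple-bonded carbon, gives a 1.0-fold lower number from compound 2 to compound 4 (0.01 log units; within the scatter), which does not separate them. Hydrogen in place of butyl at that same place gives an at least 1.1-fold lower number from compound 1 to compound 4 (0.05 log units; that floor lies within the scatter), so this step does not separate them either. Compound 1 stands at a limit: the limit of > 100000 nM in this assay, at which 1 of the 4 values shown sits.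

Open, on these data alone, is whether the phenyl ring itself matters, which a cyclohexyl in its place would test. Also open, as far as these compounds go, is how an amine or a carboxylic acid on that ring would read in this assay.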